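Benzothiophene for isoquinoline on the amide carbonyl

The source may report more compounds than this note shows. Statements on the series, on what has been measured and on what is new or still open speak of the compounds shown alone.

Series notes. The three measured compounds share one core and differ in the aryl group on the carbonyl carbon. In an assay on isolated protein for inhibition of Caspase-8 (Homo sapiens) (a lower number here means a stronger inhibitor, a higher number a weaker inhibitor), compound 1 `O=C(CN1CC=CC[C@H](NC(=O)c2cccc(Cl)c2)C1=O)N[C@H]1CC(=O)OC1O` gives 1180 nM, compound 2 `O=C(CN1CC=CC[C@H](NC(=O)c2ccc3ccccc3c2)C1=O)N[C@H]1CC(=O)OC1O` gives 2160 nM and compound 3 `O=C(CN1CC=CC[C@H](NC(=O)c2nccc3ccccc23)C1=O)N[C@H]1CC(=O)OC1O` gives 2940 nM. Compound 3 has the highest of the three numbers; against compound 2 the gap is a 1.4-fold higher number from compound 2 to compound 3 (0.13 log units; within the scatter), against compound 1 it is a 2.5-fold higher number from compound 1 to compound 3 (0.40 log units; beyond the scatter).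

Compound 4 `O=C(CN1CC=CC[C@H](NC(=O)c2cc3ccccc3s2)C1=O)N[C@H]1CC(=O)OC1O` differs from compound 3 by 1-benzothiophen-2-yl in place of isoquinolin-1-yl on a carbonyl carbon. Among the measured compounds shown here, the step that bears most on this change is the exchange of one bicyclic aryl for another, a 1.4-fold higher number from compound 2 to compound 3 (0.13 log units; within the scatter), which stayed within the scatter; the only step beyond the scatter, a 2.5-fold higher number from compound 1 to compound 3 (0.40 log units; beyond the scatter), concerns the monocyclic 3-chlorophenyl and is modest. A bicyclic-to-bicyclic exchange is therefore expected to give little movement in this assay, perhaps a slightly lower number, with the expected step of a 1.3-fold lower number from compound 3 to compound 4 (0.13 log units; within the scatter). Compound 4 is estimated at 2200 nM, with a range from 1100 nM to 4500 nM.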

Compound 4, half-maximal inhibitory concentration: 1450 nM
Compound 4: the middle estimate sits 1.5-fold (0.18 log units) above what was measured, and the stated range covers the measured number.
By their numbers in this assay, from the lowest: compounds 1, 4, 2 and 3 (each within the scatter of the next, the first and the last beyond it).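

In this assay, the exchange of one bicyclic aryl for another on the carbonyl carbon can move the number beyond the scatter, which the earlier bicyclic pair did not show (a 2.0-fold lower number from compound 3 to compound 4 (0.31 log units; beyond the scatter)), though the step is modest. The 1-benzothiophen-2-yl group is not separated from either naphthalen-2-yl (a 1.5-fold lower number from compound 2 to compound 4 (0.17 log units; within the scatter)) or 3-chlorophenyl (a 1.2-fold higher number from compound 1 to compound 4 (0.09 log units; within the scatter)), so among these four aryl groups only isoquinolin-1-yl and the 3-chlorophenyl and 1-benzothiophen-2-yl groups lie beyond the scatter of each other. No measurement offered here accounts for the step.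

Open, on these data alone, is whether the sulfur or the five-membered aromatic ring goes with the lower number, which 1-benzofuran-2-yl or indol-2-yl on the carbonyl carbon could separate. Also open, as far as these compounds go, is how a saturated cyclohexyl group or a carboxylic acid on the aryl group would read.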